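Cyano for methyl on a trifluoromethyl-bearing hydrazone scaffold

This account rests on a few compounds, and the source may have more. Where it says the series, first, only, none or still open, it means among the compounds named here.

Compound 1 `CC(=O)/C(=N\c1cccc(C#N)c1)NNc1ccccc1C`: > 10000 nM (a limit of the assay)
Compound 2 `CC(=O)/C(=N\c1cccc(C)c1)NNc1ccccc1C(F)(F)F`: 1420 nM

Among the measured compounds shown here, compound 2 is the only compound with a number in an assay on isolated protein for binding affinity to corticotropin-releasing factor receptor 1 (Homo sapiens); on this read-out lower numbers stand for stronger inhibition and higher numbers for weaker inhibition. In this assay compound 1 gives > 10000 nM, which is a limit of the assay and not a number (the limit of > 10000 nM in this assay, at which 1 of the 2 values shown sits). In this assay compound 2 gives 1420 nM. Compound 3 `CC(=O)/C(=N\c1cccc(C#N)c1)NNc1ccccc1C(F)(F)F` has not been measured; it differs from compound 2 by cyano in place of methyl on an aromatic carbon. For the measured compounds named here, no measured pair separated by this single change exists. Compound 1 also carries the cyano group but differs from compound 2 in two places, and its limit shows no more than that it sits at the top of the range. The step from compound 2 to compound 3 is expected to go toward weaker binding, beyond the scatter, as a 3.2-fold higher number from compound 2 to compound 3 (0.50 log units; beyond the scatter). Compound 3 is estimated at 4500 nM in this assay, between 1500 nM and 15000 nM.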

Compound 3, inhibition constant: > 10000 nM
Compound 3 was reported as a limit; the forecaster's own chance of this, stated with the estimate: 35%; at least 2.2-fold (0.34 log units) between middle value and limit.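

Among the compounds shown here, with the trifluoromethyl group held in place, the change from 3-methylphenyl to 3-cyanophenyl gives the first readable step at this position in this assay: an at least 7.0-fold higher number from compound 2 to compound 3 (0.84 log units; beyond the scatter). The cyano group therefore costs binding on this scaffold. Compound 3 is reported as a limit of the assay and not a number, and compound 1 sits at the same limit: the limit of > 10000 nM in this assay, at which 2 of the 3 values shown sit.

From the compounds shown here alone, the step between those two limit compounds cannot be read, so the effect of trifluoromethyl in place of methyl stays open, as does the full size of the loss from cyano. The compounds shown also leave open whether a methoxy group or a chlorine atom on the same aromatic carbon would keep the binding of compound 2.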